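Methoxy to amino on the carbonyl of compound 1

This account rests on a few compounds, and the source may have more. Where it says the series, first, only, none or still open, it means among the compounds named here.

In a functional assay on CCRF-CEM cells (Homo sapiens) for inhibition, with a stated time of 72 h (a higher number here means a weaker inhibitor, a lower number a stronger inhibitor), compound 1 (`COC(=O)C[C@H](NC(=O)OC(C)(C)C)C(=O)N(Cc1ccccc1)C1(C(=O)NCc2ccccc2)CCN(Cc2ccccc2)CC1`) gives 19000 nM, level with compound 2 (`COC(=O)C[C@H](NC(=O)OC(C)(C)C)C(=O)N(C)C1(C(=O)NCc2ccccc2)CCN(Cc2ccccc2)CC1`) at 20000 nM, while compound 3 (`COC(=O)C[C@H](NC(=O)OC(C)(C)C)C(=O)N(C1CC1)C1(C(=O)NCc2ccccc2)CCN(Cc2ccccc2)CC1`) gives 6700 nM. Compound 4 (`CC(C)(C)OC(=O)N[C@@H](CC(N)=O)C(=O)N(Cc1ccccc1)C1(C(=O)NCc2ccccc2)CCN(Cc2ccccc2)CC1`) carries amino in place of methoxy on a carbonyl carbon. Among the measured compounds shown here, no measured step touches this carbonyl. All change the substituent on an amide-type nitrogen, giving a 1.1-fold higher number from compound 1 to compound 2 (0.02 log units; within the scatter), a 2.8-fold lower number from compound 1 to compound 3 (0.45 log units; beyond the scatter) and a 3.0-fold lower number from compound 2 to compound 3 (0.47 log units; beyond the scatter). For the measured compounds named here, these steps show only the modest spread of the series so far, so they give no direction for the new change. No step beyond the scatter is expected in this assay, and the estimate is a 1.1-fold lower number from compound 1 to compound 4 (0.05 log units; within the scatter). For compound 4 the expected value is 17000 nM, with an estimated range of 6000 nM to 45000 nM.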

Compound 4, half-maximal inhibitory concentration: 26000 nM
Beside the measured number, compound 4's estimate is 1.5-fold (0.18 log units) below it; low and high end bracket the measured number.
By their numbers in this assay, from the lowest: compound 3; then compounds 1, 2 and 4 (each within the scatter of the next).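

In this assay, among the compounds shown here, the first change at this carbonyl, amino in place of methoxy on a carbonyl carbon, gives a 1.4-fold higher number from compound 1 to compound 4 (0.14 log units; within the scatter), so methoxycarbonyl and carbamoyl are not told apart on the core of compound 1. No data are available that bear on this result.

Open, from the compounds shown here alone, is whether a carboxylic acid or an ethyl ester at this carbonyl would give a step beyond the scatter. Also open, going by these compounds, is whether the same amino change would leave the number of compound 3 at 6700 nM unmoved.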